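From Imidazole to Pyridine: an Expectation for Compound 4

The source may hold more compounds than are shown below. What is called first, only, known or untested is meant among the compounds shown, and "the series" means these compounds.

Compound 1, `Cc1nn(-c2cccc(CN)c2)c2cc(-c3ccc(N4CCCCC4=O)cc3)ccc12`: > 10000 nM
Compound 2, `Cc1nn(-c2ccc3onc(N)c3c2)c2c(F)c(-c3ccc(N4CCCCC4=O)cc3F)ccc12`: > 10000 nM
Compound 3, `CN(C)Cc1nccn1-c1ccc(-c2ccc3c(C(N)=O)nn(-c4ccc5onc(N)c5c4)c3c2F)c(F)c1`: > 10000 nM

Of the compounds shown here, three have been tested in an assay on isolated protein for inhibition of Trypsin (Homo sapiens); a higher number here means a weaker inhibitor, a lower number a stronger inhibitor. For compound 1 the result of > 10000 nM is a limit of the assay and not a number. For compound 2 the result of > 10000 nM is likewise a limit. For compound 3 the result of > 10000 nM is again a limit. Going by the values given here, compound 3 therefore stands where every measured compound of this set stands, at the limit of > 10000 nM in this assay, at which 3 of the 3 values shown sit, and no step between two measured compounds can be read off, since none of them returned a number.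

Compound 4, `CN(C)Cc1cnccc1-c1ccc(-c2ccc3c(C(N)=O)nn(-c4ccc5onc(N)c5c4)c3c2F)c(F)c1`, is not yet measured. It differs from compound 3 in one place: 3-((dimethylamino)methyl)pyridin-4-yl in place of 2-((dimethylamino)methyl)-1H-imidazol-1-yl on an aromatic carbon. Among the compounds with values here, with all three values sitting at the limit, there is no measured step on which to base a direction, and the expected step in this assay is a step that the limit leaves unreadable from compound 3 to compound 4, nothing beyond the scatter. Compound 4 is accordingly estimated at 15000 nM, with a range from 5000 nM to 60000 nM, most likely to be reported again only as a limit.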

Compound 4, inhibition constant: > 10000 nM
Compound 4: a limit, no number (the forecaster's own chance of this, stated with the estimate: 85%); the middle value is on the limit's open side.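

The step from compound 3 to compound 4 cannot be read, since both results are limits and not numbers: the limit of > 10000 nM in this assay, at which 4 of the 4 values shown sit. The compounds shown leave open whether 3-((dimethylamino)methyl)pyridin-4-yl in place of 2-((dimethylamino)methyl)-1H-imidazol-1-yl changes the inhibition of trypsin at all.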